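A Second Chloro Group on Compound 2

The source may hold more compounds than are shown below. What is called first, only, known or untested is meant among the compounds shown, and "the series" means these compounds.

Compound 2 `CC(C)(C)Cc1c(-c2ccccc2)sc(N)c1C(=O)c1ccc(Cl)cc1` gives 1% in an assay on CHO cells for displacement of a labelled ligand from adenosine receptor A1 (Homo sapiens), read by scintillation counting, tested at 10 uM (on this read-out lower numbers stand for less inhibition and higher numbers for more inhibition at the one concentration tested (going by the name of the read-out)), level with compound 1 `CC(C)(C)Cc1c(-c2ccc(Cl)c(Cl)c2)sc(N)c1C(=O)c1ccc(Cl)cc1`, which gives 1%. Compound 3 `CC(C)(C)Cc1c(-c2ccccc2)sc(N)c1C(=O)c1ccc(Cl)c(Cl)c1` differs from compound 2 by chloro in place of hydrogen on an aromatic carbon, which read one bond further out is 4-chlorophenyl to 3,4-dichlorophenyl. Within the data shown here, the only measured step, no change at the digits printed from compound 1 to compound 2 (within the scatter), concerned a different ring and stayed within the scatter, so neither halogen pattern seen so far has moved the read-out. Compound 3 is therefore expected to show a number 1 percentage points higher from compound 2 to compound 3 (within the scatter), nothing beyond the scatter. For compound 3 the estimate is 2%, ranging from -8% to 12%.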

Compound 3, a percentage reported as inhibition, at one concentration (the size of the read-out at that concentration, not a potency): 1%
Compound 3: the middle estimate sits 1 percentage points above what was measured; measured number inside the range.
By their numbers in this assay, from the lowest: compounds 1, 2 and 3 (each within the scatter of the next).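

The change from 4-chlorophenyl to 3,4-dichlorophenyl gives no change at the digits printed from compound 2 to compound 3 (within the scatter) in this assay and extends the flat picture to this second aryl ring. A chloro group on this carbon, ortho to a chloro group and meta to a large group, leaves the read-out where it was, just as the dichloro pattern on the other ring did. No evidence on hand accounts for this result. From the compounds shown here alone, whether an amine or a carboxylic acid at this position would lift the number stays open, as does the effect of a longer chain there.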